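This account rests on a few compounds, and the source may have more. Where it says the series, first, only, none or still open, it means among the compounds named here.

Values so far in a functional assay for inhibition, with Homo sapiens as the target (on this read-out higher numbers stand for weaker binding and lower numbers for tighter binding), are these:
compound 1 `O=C(O)CC/C=C\CC1COC(c2ccc(C(F)(F)F)cc2)OC1c1cccnc1` gives 1780 nM
compound 2 `O=C(O)CC/C=C\CC1COC(c2cccs2)OC1c1cccnc1` gives 1000 nM
compound 3 `Cc1ccc(C#N)c(OC(C)(C)C2OCC(C/C=C\CCC(=O)O)C(c3cccnc3)O2)c1` gives 15.9 nM

Compound 3 has the lowest number of the three, and its distance to each of the other two lies beyond the scatter. Compound 4 `CC(C)(C)c1ccc(OC(C)(C)C2OCC(C/C=C\CCC(=O)O)C(c3cccnc3)O2)cc1` has not been measured. It carries 4-(tert-butyl)phenyl in place of 2-cyano-5-methylphenyl on an oxygen on a saturated carbon and keeps the rest of compound 3 unchanged. For the measured compounds named here, the only measured step (a 1.8-fold lower number from compound 1 to compound 2 (0.25 log units; within the scatter)) concerns a group on a saturated ring carbon, so it gives little guidance here. Going by the values given here, no measured step changes the group on that oxygen. Since compound 3 at 15.9 nM is the lowest value seen, a moderate rise in the number is expected, with wide uncertainty. The step expected in this assay is a 2.8-fold higher number from compound 3 to compound 4 (0.45 log units; beyond the scatter) by this estimate. Compound 4 is expected at 45 nM within an estimated range from 10 nM to 200 nM for now.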

Compound 4, dissociation constant: 1910 nM
For compound 4 the middle estimate is 42-fold (1.63 log units) below the measured one, and the stated range ends below it.
By their numbers in this assay, from the lowest: compound 3; then compounds 2, 1 and 4 (each within the scatter of the next).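

In this assay, for the compounds shown here, the group on an oxygen on a saturated carbon proves highly sensitive to change: 4-(tert-butyl)phenyl in place of 2-cyano-5-methylphenyl gives a 120-fold higher number from compound 3 to compound 4 (2.08 log units; beyond the scatter), whereas the one earlier step, at a group on a saturated ring carbon, gave a 1.8-fold lower number from compound 1 to compound 2 (0.25 log units; within the scatter). Both groups at this oxygen have one six-membered aromatic ring of carbon only, so the large step arises without a change in that ring type; what differs is the substitution, including loss of the nitrile and its hydrogen-bond acceptor. No available evidence explains the size of this step.

The two groups differ in more than one substituent, so the compounds shown do not separate the contributions of the nitrile, the methyl and the tert-butyl. On these data alone, how a plain phenyl, or a phenyl carrying an amine, would behave at this oxygen remains open.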